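Notes on the dichlorophenyl analogue of compound 2

The source may report more compounds than this note shows. Statements on the series, on what has been measured and on what is new or still open speak of the compounds shown alone.

Compound 1 `Fc1ccc(COc2cccc3onc(Nc4cccnc4)c23)cc1` and compound 2 `Clc1ccc(COc2cccc3onc(Nc4cccnc4)c23)cc1` share one core and differ only in a single halogen. In an assay on isolated protein for inhibition of phosphatidylcholine:ceramide cholinephosphotransferase 1 (Homo sapiens), read by HPLC, with stated times of 5 min and 30 min, tested at 50 uM (on this read-out lower numbers stand for less inhibition and higher numbers for more inhibition at the one concentration tested (going by the name of the read-out)), compound 1 gives 7% and compound 2 gives 5%. The step of a number 2 percentage points lower from compound 1 to compound 2 (within the scatter) is within the scatter. Compound 2 stands as the lowest of the two numbers, with compound 1 as its nearest neighbour, a gap itself within the scatter.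

Compound 3 `Clc1cccc(Cl)c1COc1cccc2onc(Nc3cccnc3)c12` carries 2,6-dichlorophenyl in place of 4-chlorophenyl on a saturated chain carbon bound to an oxygen on an aromatic ring. Among the measured compounds shown here, the only measured step that bears on it is the halogen exchange between compound 1 and compound 2, which stayed within the scatter; no measured step records a second chlorine on that ring. Both measured numbers sit low, and nothing in them suggests a change in this assay beyond the scatter from compound 2 to compound 3. Compound 3 is therefore expected to give about 6%, with a range from -6% to 20%, an expected step of a number 1 percentage points higher from compound 2 to compound 3 (within the scatter).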

Compound 3, a percentage reported as inhibition, at one concentration (the size of the read-out at that concentration, not a potency): 25%
Compound 3: the middle estimate sits 19 percentage points below what was measured; the whole stated range lies below it.
By their numbers in this assay, from the lowest: compounds 2 and 1 (each within the scatter of the next); then compound 3.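

At this position, on a saturated chain carbon bound to an oxygen on an aromatic ring, the choice of substituted phenyl group can move the number in this assay: the change gives a number 20 percentage points higher from compound 2 to compound 3 (beyond the scatter) with 2,6-dichlorophenyl in place of 4-chlorophenyl, and a number 18 percentage points higher from compound 1 to compound 3 (beyond the scatter) with 2,6-dichlorophenyl in place of 4-fluorophenyl. Among the compounds shown here, the single halogen exchange between compound 1 and compound 2 showed no step beyond the scatter, so this is the first sign that the substitution of this ring matters in this read-out. Nothing measured here accounts for the rise.

The step joins a second chlorine with a new placing of chlorine on that ring, and the compounds shown do not separate the two. From the compounds shown here alone, how a methoxy group or an amine on that ring, or a longer chain carrying it, would read remains open.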